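Chloro in Place of Bromo: Expecting the Value of Compound 4

This account rests on a few compounds, and the source may have more. Where it says the series, first, only, none or still open, it means among the compounds named here.

Compound 1, `O=C(Nc1ccc(Br)c(Cl)c1)c1cc(F)ccc1O`: 670 nM
Compound 2, `N#Cc1ccc(NC(=O)c2cc(-c3ccncc3)ccc2O)cc1`: 7990 nM
Compound 3, `N#Cc1ccc(NC(=O)c2ccc(-c3cccnc3)cc2O)cc1`: 7940 nM

Of the compounds shown here, three have been tested in a functional assay on KG-1 cells (Homo sapiens) for cytotoxicity, read by luminescence and CellTiter-Glo, with a stated time of 3 days; a lower number here means a stronger inhibitor, a higher number a weaker inhibitor. Compound 1 gives the lowest of the three numbers, 670 nM, and both other compounds sit well beyond the scatter above it. Compound 2 gives 7990 nM and compound 3 gives 7940 nM; these two values lie within the scatter of each other, so nothing separates them. Compound 1 thus stands as the strongest inhibitor of the set, while compounds 2 and 3 share a much weaker level.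

Compound 4, `O=C(Nc1ccc(Cl)c(Cl)c1)c1cc(F)ccc1O`, has not yet been measured. It keeps the core of compound 1 and differs in one place only: chloro in place of bromo on an aromatic carbon. Among the measured compounds shown here, no pair of measured compounds shows what this kind of exchange does here, so no measured step can be cited.

Because compound 1 gives 670 nM and the change is limited to one halogen for another, the step from compound 1 to compound 4 is expected to be small, a 1.2-fold higher number from compound 1 to compound 4 (0.08 log units; within the scatter), with no clear direction beyond the scatter. Compound 4 is therefore estimated at 800 nM in this assay, within a range of 350 nM to 1800 nM.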

Compound 4, half-maximal inhibitory concentration: 760 nM
Beside the measured number, compound 4's estimate is 1.1-fold (0.02 log units) above it, and the stated range covers the measured number.
By their numbers in this assay, from the lowest: compounds 1 and 4 (each within the scatter of the next); then compounds 3 and 2 (each within the scatter of the next).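

Chloro in place of bromo is the first exchange in this set where two compounds differ in one place only, so it gives the first direct reading of a single change on the shared core. The change sits on an aromatic carbon of a six-membered aromatic ring of carbon only, ortho to a chloro group and para to a large group, and in this assay it amounts to a 1.1-fold higher number from compound 1 to compound 4 (0.05 log units; within the scatter), so this assay does not tell bromo and chloro apart at this position. The result describes what the numbers do, and nothing available explains why the two compounds read alike.

The compounds shown carry only these two halogens at this position, so they leave open whether a quite different group there, such as a methyl group, a methoxy group, an amine or a carboxylic acid, would keep the number at this level or move it well beyond the scatter. Among the compounds shown here, they also leave open what the chloro group ortho to this carbon contributes, as no pair of compounds differs at that place alone.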